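The compounds below may be only part of what the source reports. "The series", "measured", "known", "first", "only" and "open" are said of these compounds alone.

In a functional assay on FM3A cells (Mus musculus) for cytotoxicity (a lower number here means that less compound is needed, a higher number that more compound is needed for the effect), compound 1 `C=C(C)COOC1(OOC)CCCCCCCCCCC1` gives 17000 nM and compound 2 `COOC1(OOCCCc2ccccc2)CCCCCCCCCCC1` gives 34000 nM while compound 3 `COOC1(OOCCCCCCO)CCCCCCCCCCC1` gives 1600 nM as the lowest number of the three. Compound 4 `COOC1(OOCCCCCC(=O)O)CCCCCCCCCCC1` has not yet been measured. Its difference from compound 3 is carboxy in place of hydroxymethyl on a saturated chain carbon, five bonds along the chain from an oxygen and in words it is carboxy in place of hydroxymethyl on a saturated chain carbon, five bonds along the chain from an oxygen.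

Among the measured compounds shown here, no measured step makes this exact swap, so the evidence is indirect. Putting 5-hydroxypentyl in place of 1-methylethenyl gave an 11-fold lower number from compound 1 to compound 3 (1.03 log units; beyond the scatter) and putting 3-hydroxypropyl in place of phenyl gave a 21-fold lower number from compound 2 to compound 3 (1.33 log units; beyond the scatter) as a second large step. By contrast, a 2.0-fold higher number from compound 1 to compound 2 (0.30 log units; within the scatter) shows that a swap without the hydroxyl-bearing chain need not move the number. Compound 4 loses the hydroxymethyl of that chain, so part of the gain may be lost, but three compounds cannot show how much. The expected change is a 3.1-fold higher number from compound 3 to compound 4 (0.49 log units; beyond the scatter) as a rough estimate. For compound 4 the estimated value is 5000 nM with an expected range from 1300 nM to 20000 nM in this assay.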

Compound 4, half-maximal effective concentration: 14000 nM
Estimate against measurement, compound 4: 2.8-fold (0.45 log units) below; low and high end bracket the measured number.
By their numbers in this assay, from the lowest: compound 3; then compounds 4, 1 and 2 (each within the scatter of the next, the first and the last beyond it).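

In this assay the swap of hydroxymethyl for carboxy at the end of the chain gives an 8.8-fold higher number from compound 3 to compound 4 (0.94 log units; beyond the scatter) and so shows that this position responds to the end group itself, not only to the presence of a chain. The carboxy chain also compares differently with the two other side groups, with a 2.4-fold lower number from compound 2 to compound 4 (0.39 log units; beyond the scatter) on one side and a 1.2-fold lower number from compound 1 to compound 4 (0.08 log units; within the scatter) on the other, so compound 4 does not keep the clear separation from compound 1 that compound 3 has. Nothing measured here gives a reason for the effect of this swap.

Going by these compounds, it remains open whether the hydroxyl itself matters or whether any small neutral end group would serve as well, which an amine, a methyl ester or a methoxy group at the same place could test. A longer or shorter hydroxyl-bearing chain would show how much the chain length contributes.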